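Swapping the arylidene: thiophene for dimethylaminophenyl

The compounds below may be only part of what the source reports. "The series", "measured", "known", "first", "only" and "open" are said of these compounds alone.

Three compounds of the series have numbers in a functional assay on DU-145 cells (Homo sapiens) for cytotoxicity, read by sulforhodamine B assay, with a stated time of 48 h; on this read-out lower numbers stand for stronger inhibition and higher numbers for weaker inhibition. Compound 1 `CC(=O)OC[C@H]1O[C@@H](n2cc(CN3C(=O)/C(=C/c4ccccc4)c4ccccc43)nn2)[C@H](OC(C)=O)[C@@H](OC(C)=O)[C@@H]1OC(C)=O` gives 22800 nM; compound 2 `CC(=O)OC[C@H]1O[C@@H](n2cc(CN3C(=O)/C(=C\c4ccc(N(C)C)cc4)c4ccccc43)nn2)[C@H](OC(C)=O)[C@@H](OC(C)=O)[C@@H]1OC(C)=O` gives 10100 nM; compound 3 `CC(=O)OC[C@H]1O[C@@H](n2cc(CN3C(=O)/C(=C/c4ccc(N(C)C)cc4)c4ccccc43)nn2)[C@H](OC(C)=O)[C@@H](OC(C)=O)[C@@H]1OC(C)=O` gives 11200 nM. On these numbers compound 3 stands second highest of the three: compound 2 is nearest, and the pair show only a 1.1-fold higher number from compound 2 to compound 3 (0.04 log units; within the scatter), the two compounds differing only in the drawn double-bond geometry (the fact that compounds 2 and 3 differ only in the configuration as drawn). Compound 1 is furthest, and the step is a 2.0-fold lower number from compound 1 to compound 3 (0.31 log units; beyond the scatter).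

Compound 4 `CC(=O)OC[C@H]1O[C@@H](n2cc(CN3C(=O)/C(=C/c4cccs4)c4ccccc43)nn2)[C@H](OC(C)=O)[C@@H](OC(C)=O)[C@@H]1OC(C)=O` has not been measured. Its change from compound 3 is thiophen-2-yl in place of 4-(dimethylamino)phenyl on a double-bonded chain carbon bound to a double-bonded ring carbon. Going by the values given here, no measured step swaps one aromatic ring for another, so only the step from compound 1 to compound 3 bears on it: that step shows that the dimethylamino group, present in compound 3 and absent in compound 4, was worth a modest lowering of the number. Without it, and with a smaller ring in place of the phenyl, the expected step of a 1.6-fold higher number from compound 3 to compound 4 (0.21 log units; within the scatter) is a modest rise in the number, toward where compound 1 stands. The estimate for compound 4 in this assay is therefore 18000 nM, in a range from 8000 nM to 45000 nM.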

Compound 4, half-maximal inhibitory concentration: 23400 nM
Beside the measured number, compound 4's estimate is 1.3-fold (0.11 log units) below it; low and high end bracket the measured number.
By their numbers in this assay, from the lowest: compounds 2 and 3 (each within the scatter of the next); then compounds 1 and 4 (each within the scatter of the next).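

Going by these compounds alone, the swap of 4-(dimethylamino)phenyl for thiophen-2-yl in this assay gives a 2.1-fold higher number from compound 3 to compound 4 (0.32 log units; beyond the scatter) as the first measured change of aromatic ring on a double-bonded chain carbon bound to a double-bonded ring carbon, and this is a modest step beyond the scatter. Set against plain phenyl, thiophen-2-yl gives a 1.0-fold higher number from compound 1 to compound 4 (0.01 log units; within the scatter) and cannot be told apart from it, so within these compounds a change of ring alone does not move the number, while the two compounds carrying 4-(dimethylamino)phenyl sit lower. Nothing measured here accounts for either step.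

Going by these compounds, whether a dimethylamino group on the thiophene ring would lower the number as it does on phenyl remains open. So does the effect of a morpholine, a carboxylic acid or a pyridine ring at this place.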